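Para substituent swap on the phenyl-triazole of compound 3

The compounds below may be only part of what the source reports. "The series", "measured", "known", "first", "only" and "open" are said of these compounds alone.

Measured so far in a functional assay on A-431 cells (Homo sapiens) for cytotoxicity, read by MTT assay, with a stated time of 24 h; a higher number here means a weaker inhibitor, a lower number a stronger inhibitor:
compound 1 `COc1ccc(/C=C\C(=O)O)c(OCc2cn(-c3ccccc3C(=O)N3CCC(O)C3)nn2)c1CC=C(C)C` gives 31500 nM
compound 2 `COc1ccc(/C=C\C(=O)O)c(OCc2cn(-c3ccccc3I)nn2)c1CC=C(C)C` gives 32700 nM
compound 3 `COc1ccc(/C=C\C(=O)O)c(OCc2cn(-c3ccc(CO)cc3)nn2)c1CC=C(C)C` gives 16400 nM

Compound 3 is not separated from compound 1 or from compound 2 beyond the scatter in this assay. The two measured steps, a 1.0-fold higher number from compound 1 to compound 2 (0.02 log units; within the scatter) and a 2.0-fold lower number from compound 2 to compound 3 (0.30 log units; within the scatter), both fall within the scatter, so this series has so far shown no change on the aryl group of the triazole that moves the number.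

Compound 4 `COc1ccc(/C=C\C(=O)O)c(OCc2cn(-c3ccc(C#N)cc3)nn2)c1CC=C(C)C` differs from compound 3 by cyano in place of hydroxymethyl on an aromatic carbon. Neither measured step covers this exchange, and none of them moved the number beyond the scatter, so no step beyond the scatter is expected in this assay, a 1.0-fold higher number from compound 3 to compound 4 (0.02 log units; within the scatter). Compound 4 is therefore estimated at 17000 nM, with a range from 7000 nM to 40000 nM.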

Compound 4, half-maximal inhibitory concentration: 23000 nM
The estimate for compound 4 lay 1.4-fold (0.13 log units) below the measured number; low and high end bracket the measured number.
By their numbers in this assay, from the lowest: compounds 3, 4, 1 and 2 (each within the scatter of the next).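

In this assay, the exchange at this place, on an aromatic carbon para to a large group, gives a 1.4-fold higher number from compound 3 to compound 4 (0.15 log units; within the scatter), so removing the hydrogen-bond donor of hydroxymethyl does not move the number beyond the scatter. The aryl exchange on the triazole nitrogen gives a 1.4-fold lower number from compound 2 to compound 4 (0.15 log units; within the scatter), which is also within the scatter. No supporting data bear on these results.

Still open, as far as these compounds go, is whether an amine or a carboxylic acid at this place would produce a step beyond the scatter. A longer chain carrying a terminal hydroxyl is equally unresolved.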